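Replacing a chlorophenyl with a methoxyphenylethyl in a sulfonamide series

The source may hold more compounds than are shown below. What is called first, only, known or untested is meant among the compounds shown, and "the series" means these compounds.

Three sulfonamido-benzoic acids have numbers in an assay on mitochondria (strain BALB/c) for inhibition of glycerol-3-phosphate acyltransferase 1, mitochondrial (Mus musculus), read by scintillation counting, with a stated time of 10 min (on this read-out lower numbers stand for stronger inhibition and higher numbers for weaker inhibition), so far. Compound 1 `CCCCCCCCS(=O)(=O)Nc1cc(-c2ccccc2-c2ccccc2)ccc1C(=O)O` gives 17100 nM in this assay. Compound 2 `CCCCCCCCS(=O)(=O)Nc1ccc(-c2ccc(Cl)cc2)cc1C(=O)O` gives 9200 nM in this assay. Compound 3 `CCCCCCCCS(=O)(=O)Nc1ccc(C(=O)c2ccc(CCCC)cc2)cc1C(=O)O` gives 31700 nM in this assay. Compound 2 has the lowest of the three numbers; its gap to compound 1 falls within the usual scatter, so no order between those two can be claimed, while its gap to compound 3 lies beyond the scatter.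

Compound 4 `CCCCCCCCS(=O)(=O)Nc1ccc(CCc2ccc(OC)cc2)cc1C(=O)O` has not yet been measured in this assay. It differs from compound 2 in one place: 2-(4-methoxyphenyl)ethyl in place of 4-chlorophenyl on an aromatic carbon. Within the data shown here, no pair of measured compounds differs in that single way, so the data hold no direct precedent for this exchange.

The step from compound 2 to compound 4 is expected to be modest, toward a higher number in this assay, near the edge of the scatter rather than far beyond it, as a 1.6-fold higher number from compound 2 to compound 4 (0.21 log units; within the scatter). Compound 4 is expected to give about 15000 nM in this assay, in a range from 5000 nM to 45000 nM.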

Compound 4, half-maximal inhibitory concentration: 26300 nM
For compound 4 the middle estimate is 1.8-fold (0.24 log units) below the measured one, and the stated range covers the measured number.
By their numbers in this assay, from the lowest: compounds 2, 1, 4 and 3 (each within the scatter of the next, the first and the last beyond it).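

In this assay the series gains its first exchange at a single place (a 2.9-fold higher number from compound 2 to compound 4 (0.46 log units; beyond the scatter)), and this step lies beyond the scatter. It shows that on this aromatic carbon, meta to a carboxy group and para to a large group, 4-chlorophenyl gives the lower number and 2-(4-methoxyphenyl)ethyl the higher one, even though both groups hold one six-membered aromatic ring of carbon only. The entering group has more heavy atoms, trades chlorine for oxygen and adds a hydrogen-bond acceptor, but no measurement here bears on which of these differences matters or why the number rises.

The exchange changes the ethyl link and the group on the ring together, so the step cannot be divided between them: 2-(4-chlorophenyl)ethyl or 4-methoxyphenyl on the same carbon would be needed to separate the two parts. Going by these compounds, how an amine or a carboxylic acid in place of the methoxy group, or a longer chain in place of the ethyl link, would read in this assay also remains open.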